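Methyl to chloro beside the carboxy-bearing ring

The source may hold more compounds than are shown below. What is called first, only, known or untested is meant among the compounds shown, and "the series" means these compounds.

Measured compounds:
- compound 1, `COc1cc(C(=O)O)ccc1OC[C@H](C)COc1ccc(C(=O)CC(C)(C)C)c(O)c1C`: 512 nM
- compound 2, `Cc1cc(C(=O)O)ccc1OC[C@H](C)COc1ccc(C(=O)CC(C)(C)C)c(O)c1C`: 1520 nM

In an assay for positive allosteric modulation of metabotropic glutamate receptor 3 (Rattus norvegicus) (a higher number here means that more compound is needed for the effect, a lower number that less compound is needed), compound 2 gives 1520 nM, the highest of the two numbers in hand; the nearest is compound 1 at 512 nM. Within the data shown here, the one step between the two, a 3.0-fold higher number from compound 1 to compound 2 (0.47 log units; beyond the scatter), is a methyl in place of a methoxy on the aromatic carbon that also carries the variation now in question.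

Compound 3, `Cc1c(OC[C@@H](C)COc2ccc(C(=O)O)cc2Cl)ccc(C(=O)CC(C)(C)C)c1O`, differs from compound 2 by chloro in place of methyl on an aromatic carbon; the site is on an aromatic carbon of a six-membered aromatic ring of carbon only, ortho to a large group and meta to a carboxy group. Among the measured compounds shown here, the only measured step at this position, a 3.0-fold higher number from compound 1 to compound 2 (0.47 log units; beyond the scatter), compares methoxy with methyl; no measured pair compares methyl with chloro. Since the two groups match in heavy-atom count and in donor and acceptor count, the step is expected to stay within the scatter, a 1.0-fold lower number from compound 2 to compound 3 (0.01 log units; within the scatter).

Compound 3 is therefore estimated at 1500 nM in this assay, with a range of 500 nM to 4500 nM.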

Compound 3, half-maximal effective concentration: 1650 nM
Compound 3: middle estimate off by 1.1-fold (0.04 log units), on the low side; the range from low to high includes it.
By their numbers in this assay, from the lowest: compound 1; then compounds 2 and 3 (each within the scatter of the next).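

In working terms, methyl and chloro now have a direct comparison at this position on the carboxy-bearing ring, and the change from 4-carboxy-2-methylphenyl to 4-carboxy-2-chlorophenyl in this assay does not separate them (step: a 1.1-fold higher number from compound 2 to compound 3 (0.04 log units; within the scatter)). Methoxy is now set against two groups rather than one, and the second comparison (step: a 3.2-fold higher number from compound 1 to compound 3 (0.51 log units; beyond the scatter)) lies beyond the scatter, as did the first (step: a 3.0-fold higher number from compound 1 to compound 2 (0.47 log units; beyond the scatter)), so compound 1 stands apart from both compound 2 and compound 3. Nothing at hand bears on the reason for this result.

From the compounds shown here alone, it remains open whether the lower number of compound 1 is particular to methoxy or would also appear with ethoxy, hydroxy or an amine at this site. Fluoro, a nitrile and a longer alkyl chain are also untested here among the compounds shown.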